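The source may report more compounds than this note shows. Statements on the series, on what has been measured and on what is new or still open speak of the compounds shown alone.

In a functional assay on the whole organism for inhibition, with Scenedesmus acutus as the target (a lower number here means a stronger inhibitor, a higher number a weaker inhibitor), compound 1 `O=C1C2=C(CCCC2)C(=O)N1c1ccc(Cl)cc1F` gives 37.2 nM, compound 2 `COC(=O)c1cc(N2C(=O)C3=C(CCCC3)C2=O)c(F)cc1Cl` gives 67.6 nM and compound 3 `CCCOC(=O)c1cc(N2C(=O)C3=C(CCCC3)C2=O)c(F)cc1Cl` gives 33.1 nM. The numbers show a 1.1-fold lower number from compound 1 to compound 3 (0.05 log units; within the scatter), which places these two level, and a 2.0-fold lower number from compound 2 to compound 3 (0.31 log units; beyond the scatter), which leaves compound 3 clearly on the lower side of that pair. The unmeasured compound 4 `CC(C)COC(=O)c1cc(N2C(=O)C3=C(CCCC3)C2=O)c(F)cc1Cl` differs from compound 3 by methyl in place of hydrogen on a saturated chain carbon bound to two saturated chain carbons, so that propoxy becomes isobutoxy. The closest guide is the step that added ethyl on the same chain, a 2.0-fold lower number from compound 2 to compound 3 (0.31 log units; beyond the scatter), which is modest. The remaining step, a 1.8-fold higher number from compound 1 to compound 2 (0.26 log units; within the scatter), stays inside the scatter, as does the step to compound 3 from compound 1. A single added methyl is therefore not expected to move the number much. The estimate is a 1.1-fold lower number from compound 3 to compound 4 (0.03 log units; within the scatter), with no change expected beyond the scatter. For compound 4 the expected value is 31 nM, with an estimated range of 16 nM to 60 nM.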

Compound 4, half-maximal inhibitory concentration: 100 nM
The estimate for compound 4 lay 3.2-fold (0.51 log units) below the measured number; measured number above the stated range.
By their numbers in this assay, from the lowest: compounds 3, 1, 2 and 4 (each within the scatter of the next, the first and the last beyond it).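

In this assay, one methyl on the saturated chain carbon bound to two saturated chain carbons, turning propoxy into isobutoxy, is enough to shift the number (a 3.0-fold higher number from compound 3 to compound 4 (0.48 log units; beyond the scatter)), so this part of the chain is not indifferent to a small addition. The ester chain does not act in one direction: the advantage of propoxycarbonyl over methoxycarbonyl is lost with isobutoxycarbonyl (a 1.5-fold higher number from compound 2 to compound 4 (0.17 log units; within the scatter)), and isobutoxycarbonyl in place of hydrogen on the aromatic carbon, unlike propoxycarbonyl, gives a step beyond the scatter (a 2.7-fold higher number from compound 1 to compound 4 (0.43 log units; beyond the scatter)). Nothing given here accounts for this shift.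

The compounds shown leave open whether the branch or the extra carbon matters, a question that a straight butyl ester would address. They also leave open how a carboxylic acid or an amide in place of the ester would read in this assay.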